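Halogen swap on an aryl urea and its semicarbazide analogue

The source may report more compounds than this note shows. Statements on the series, on what has been measured and on what is new or still open speak of the compounds shown alone.

Measured so far:
compound 1, `COc1cc(NC(C)CCCNC(=O)Nc2cccc(F)c2)c2ncccc2c1`, 21000 nM
compound 2, `COc1cc(NC(C)CCCNC(=O)Nc2cccc(Cl)c2)c2ncccc2c1`, 22000 nM
compound 3, `COc1cc(NC(C)CCCNC(=O)NNC(=O)Nc2ccc(F)cc2)c2ncccc2c1`, 118000 nM

All three compounds share one core and were tested in a functional assay on CCRF-CEM cells (Homo sapiens) for inhibition, read by MTT assay, with a stated time of 72 h; a higher number here means a weaker inhibitor, a lower number a stronger inhibitor. Compound 1 gives 21000 nM and compound 2 gives 22000 nM; the two differ only by chloro in place of fluoro on an aromatic carbon, and the step of a 1.0-fold higher number from compound 1 to compound 2 (0.02 log units; within the scatter) shows that this change left the number essentially where it was. Compound 3 carries a longer group, described by ((4-fluorophenyl)carbamoyl)amino in place of 3-fluorophenyl on an amide-type nitrogen, and in this assay compound 3 gives 118000 nM. The steps of a 5.6-fold higher number from compound 1 to compound 3 (0.75 log units; beyond the scatter) and a 5.4-fold higher number from compound 2 to compound 3 (0.73 log units; beyond the scatter) are both beyond the scatter, so among these three compound 3 gives the highest number.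

Compound 4, `COc1cc(NC(C)CCCNC(=O)NNC(=O)Nc2ccc(Cl)cc2)c2ncccc2c1`, has not yet been measured in this assay. It differs from compound 3 by chloro in place of fluoro on an aromatic carbon. Within the data shown here, this is the same kind of change as the one from compound 1 to compound 2, but not the same: there the halogen sat meta to a large group, here it sits para to a large group. The expectation for compound 4 rests on the earlier swap, a 1.0-fold higher number from compound 1 to compound 2 (0.02 log units; within the scatter), which stayed within the scatter. On that basis the step from compound 3 to compound 4 is expected to be a 1.0-fold higher number from compound 3 to compound 4 (0.01 log units; within the scatter). Compound 4 is therefore estimated to give about 120000 nM, most likely between 60000 nM and 240000 nM.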

Compound 4, half-maximal inhibitory concentration: 108000 nM
Estimate against measurement, compound 4: 1.1-fold (0.05 log units) above, within the range that was stated.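

In this assay, chloro in place of fluoro gives a 1.1-fold lower number from compound 3 to compound 4 (0.04 log units; within the scatter), and this step does not differ from the one seen earlier on the other core: the same change on two cores in this assay, a 1.0-fold higher number (0.02 log units; within the scatter) from compound 1 to compound 2 and a 1.1-fold lower number (0.04 log units; within the scatter) from compound 3 to compound 4, 1.1-fold (0.06 log units) apart, within the scatter of two such steps. So on the two cores shown, this halogen swap left the number essentially unchanged both times, whereas the longer group on the amide-type nitrogen does move it, with a 4.9-fold higher number from compound 2 to compound 4 (0.69 log units; beyond the scatter) and a 5.1-fold higher number from compound 1 to compound 4 (0.71 log units; beyond the scatter). This does not show that the swap would be equally silent on any other core or at any other place on the ring, as it rests on just two pairs of compounds, and the halogen does not occupy the same place on the ring in the two pairs.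

The compounds shown leave open whether a group other than these two halogens, such as trifluoromethyl or a nitrile, would also leave the number unchanged on the aromatic ring. They also leave open how much of the step to the longer compounds belongs to the added nitrogen and carbonyl and how much to the different place of the halogen.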